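Swapping the benzyl substituent on the triazole of compound 2

The compounds below may be only part of what the source reports. "The series", "measured", "known", "first", "only" and "open" are said of these compounds alone.

In a functional assay on RAW264.7 cells (Mus musculus) for inhibition, read by Griess assay, with stated times of 2 h and 24 h (a lower number here means a stronger inhibitor, a higher number a weaker inhibitor), compound 2 `COc1ccc([C@@H]2CC(=O)c3c(O)cc(OCc4cn(Cc5ccccc5C(F)(F)F)nn4)cc3O2)cc1O` gives 12500 nM. Among the three measured compounds it stands second highest; compound 1 `C#CCOc1cc(O)c2c(c1)O[C@H](c1ccc(OC)c(O)c1)C/C2=N\O` gives 19100 nM, which lies within the scatter of compound 2, while compound 3 `COc1ccc([C@@H]2C/C(=N\O)c3c(O)cc(OCc4cn(Cc5ccccc5F)nn4)cc3O2)cc1O` gives 5710 nM, a lower number that lies beyond the scatter. Compound 3 differs from compound 2 in more than one place, so only the two values themselves can be compared. Compound 4 `COc1ccc([C@@H]2CC(=O)c3c(O)cc(OCc4cn(Cc5ccc(C)cc5)nn4)cc3O2)cc1O` differs from compound 2 by 4-methylphenyl in place of 2-(trifluoromethyl)phenyl on a saturated chain carbon bound to an aromatic nitrogen. Among the measured compounds shown here, no measured pair isolates this change. Compound 4 is therefore expected to stay close to compound 2, with the step of a 1.3-fold lower number from compound 2 to compound 4 (0.10 log units; within the scatter) expected to remain within the scatter in this assay. The estimated value of compound 4 is 10000 nM, with a range from 4000 nM to 25000 nM.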

Compound 4, half-maximal inhibitory concentration: 16800 nM
The estimate for compound 4 lay 1.7-fold (0.23 log units) below the measured number; low and high end bracket the measured number.
By their numbers in this assay, from the lowest: compound 3; then compounds 2, 4 and 1 (each within the scatter of the next).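

In this assay, 4-methylphenyl in place of 2-(trifluoromethyl)phenyl on a saturated chain carbon bound to an aromatic nitrogen gives a 1.3-fold higher number from compound 2 to compound 4 (0.13 log units; within the scatter). Among the compounds shown here, this is the first pair in the set that differs in one place, and it shows that this position accepts either of these two substituted phenyl groups while the number stays within the scatter. Nothing measured here offers an explanation for this result. From the compounds shown here alone, it remains open whether a phenyl group carrying an amine or a carboxylic acid, or a longer chain in place of the benzyl carbon, would move the number beyond the scatter.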